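A few compounds are considered here, and "the series" means these few. Any claim that something is new, unique, unknown or untested is made for them only; others in the source may bear on it.

Three compounds with the shared core, differing in the saturated chain, have been tested in a functional assay on HCT-116 cells (Homo sapiens) for antiproliferative activity, read by MTT assay, with a stated time of 48 h; on this read-out lower numbers stand for stronger inhibition and higher numbers for weaker inhibition. Compound 1 `CCCCC(CCO)n1cnc2c(OC)ncnc21` gives > 50000 nM, which is a limit of the assay and not a number. Compound 2 `CCCCCC(CCO)n1cnc2c(OC)ncnc21` gives > 50000 nM, again a limit. Among the measured compounds shown here, compound 3 `CCCCCCCC(CCO)n1cnc2c(OC)ncnc21`, with the longest chain so far, gives 15300 nM, the only true number in the set.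

Compound 4 `CCCCCCCCC(CCO)n1cnc2c(OC)ncnc21` takes the chain further, with one change: methyl in place of hydrogen on a saturated chain carbon, eight bonds along the chain from an aromatic nitrogen. The step that the two limits leave unreadable from compound 1 to compound 2 cannot be sized, so it offers little guidance. Two other steps do bear on the change: an at least 3.2-fold lower number from compound 1 to compound 3 (0.51 log units; beyond the scatter) and an at least 3.2-fold lower number from compound 2 to compound 3 (0.51 log units; beyond the scatter). Both lengthen the chain, and both lead to a lower number. The second of these added ethyl, whereas compound 4 adds only methyl, so a smaller move in the same direction is expected. The expected change is a 1.9-fold lower number from compound 3 to compound 4 (0.28 log units; within the scatter). For compound 4 the estimated value is 8000 nM, with an expected range from 3000 nM to 22000 nM.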

Compound 4, half-maximal inhibitory concentration: 12800 nM
For compound 4 the middle estimate is 1.6-fold (0.20 log units) below the measured one; the measured number falls inside the stated range.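

Methyl in place of hydrogen at this place, eight bonds along the chain from an aromatic nitrogen, gives a 1.2-fold lower number from compound 3 to compound 4 (0.08 log units; within the scatter) in this assay, so compound 3 and compound 4 cannot be told apart. The step that went beyond the scatter when the chain grew to compound 3 therefore has no readable counterpart in this further change. Compound 4 still stands clear of the shorter chains, with an at least 3.9-fold lower number from compound 2 to compound 4 (0.59 log units; beyond the scatter) and an at least 3.9-fold lower number from compound 1 to compound 4 (0.59 log units; beyond the scatter), and propyl goes with a lower number on both chains where it can be compared: the same change on two cores in this assay, an at least 3.2-fold lower number (0.51 log units; beyond the scatter) from compound 1 to compound 3 and an at least 3.9-fold lower number (0.59 log units; beyond the scatter) from compound 2 to compound 4; the limit leaves it open whether they differ.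

As far as these compounds go, the true size of the steps from the shorter chains stays open, since those compounds rest on a limit: the limit of > 50000 nM in this assay, at which 2 of the 4 values shown sit. From the compounds shown here alone, whether a longer chain, an amine or a carboxylic acid at this place would move the number beyond the scatter also stays open.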